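Indole acrylates and acrylonitriles against MCF7

This account rests on a few compounds, and the source may have more. Where it says the series, first, only, none or still open, it means among the compounds named here.

Measured in a functional assay on MCF7 cells (Homo sapiens) for cytotoxicity, read by MTT assay, with a stated time of 96 h; a higher number here means that more compound is needed for the effect, a lower number that less compound is needed:
- compound 1 `CCOC(=O)/C(=C/c1c(-c2ccccc2)[nH]c2ccccc12)C(=O)c1ccccc1` gives 43000 nM
- compound 2 `N#C/C(=C\c1c(-c2ccccc2)[nH]c2ccccc12)C(=O)c1cccs1` gives 29000 nM
- compound 3 `COc1ccc(-c2[nH]c3ccc(OC)cc3c2/C=C(\C#N)S(=O)(=O)c2ccccc2)cc1` gives 40000 nM

Compound 2 has the lowest number of the three in this assay, but the gaps to compound 3 and to compound 1 both lie within the scatter of repeated measurements, so the three compounds cannot be told apart on these data. Going by the values given here, no single-point step between measured compounds is available in this set.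

The unmeasured compound 4 `COCCOC(=O)/C(C#N)=C/c1c(-c2ccccc2)[nH]c2ccccc12` is the nitrile of compound 2 with the acyl group exchanged: 2-methoxyethoxy in place of thiophen-2-yl on a carbonyl carbon. The product keeps the nitrile and the shared core and carries an ester in place of the ketone, which brings it closer to compound 1, where an ester stands beside a benzoyl group; compound 1 shows 43000 nM, within the scatter of compound 2.

Given that all three measured compounds sit in one narrow band and that the ester of compound 1 gives no separate signal, no step beyond the scatter is expected for a 1.4-fold higher number from compound 2 to compound 4 (0.14 log units; within the scatter), with a slight lean toward a higher number. Compound 4 is therefore estimated at 40000 nM, with a likely range from 15000 nM to 100000 nM.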

Compound 4, half-maximal effective concentration: 12000 nM
Compound 4: middle estimate off by 3.3-fold (0.52 log units), on the high side, and the stated range ends above it.
By their numbers in this assay, from the lowest: compound 4; then compounds 2, 3 and 1 (each within the scatter of the next).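

In this assay, going by these compounds alone, (2-methoxyethoxy)carbonyl in place of (thiophen-2-yl)carbonyl gives a 2.4-fold lower number from compound 2 to compound 4 (0.38 log units; beyond the scatter) and is the only step that lies beyond the scatter, though it is a modest one. Within the data shown here, with the nitrile and the shared core unchanged in this pair, the group on this carbonyl carbon can shift the number, something the earlier compounds could not show, as no two of them differ in one place only. No measured evidence bears on why the number falls with this change.

The single exchange removes a ring and brings in an open chain at once, so the compounds shown do not tell whether the loss of thiophen-2-yl or the arrival of 2-methoxyethoxy accounts for the step. Also open, from the compounds shown here alone, is how far the trend extends at this carbonyl carbon, which a carboxylic acid, an amide or a longer ether chain in the same place, with the nitrile kept, would begin to answer.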